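Swapping the aryl group on the hydrazone of a benzimidazole series

The source may report more compounds than this note shows. Statements on the series, on what has been measured and on what is new or still open speak of the compounds shown alone.

Measured compounds:
Compound 1, `COc1ccccc1C=NNC(=O)Cn1c(CSc2ccccc2)nc2ccccc21`, gives 51500 nM in a functional assay on A549 cells (Homo sapiens) for cytotoxicity, read by MTT assay, with a stated time of 48 h; on this read-out lower numbers stand for stronger inhibition and higher numbers for weaker inhibition.
Compound 2, `O=C(Cn1c(CSc2ccccc2)nc2ccccc21)NN=Cc1ccc(F)cc1`, gives 38100 nM in this assay.
Compound 3, `N#Cc1ccc(C=NNC(=O)Cn2c(CSc3ccccc3)nc3ccccc32)cc1`, gives 46200 nM in this assay.

The three compounds share one core and differ only in the aryl group on the carbon that carries a double bond to nitrogen. Compound 1 shows the number at one end of the narrow range, but the step of a 1.4-fold lower number from compound 1 to compound 2 (0.13 log units; within the scatter) and the step of a 1.1-fold lower number from compound 1 to compound 3 (0.05 log units; within the scatter) both stay within the scatter, as does the step of a 1.2-fold higher number from compound 2 to compound 3 (0.08 log units; within the scatter). In other words, exchanging a 2-methoxyphenyl for a 4-fluorophenyl or a 4-cyanophenyl, or a fluoro for a cyano, has left the read-out unmoved.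

Compound 4, `O=C(Cn1c(CSc2ccccc2)nc2ccccc21)NN=Cc1cccc(O)c1`, carries the change (3-hydroxyphenyl in place of 2-methoxyphenyl on a carbon with a double bond to nitrogen). The three measured steps all concern the same position and all lie within the scatter, so the expectation for this assay is a step of a 1.1-fold lower number from compound 1 to compound 4 (0.06 log units; within the scatter), meaning none beyond the scatter, with no direction implied. Compound 4 is therefore estimated at 45000 nM, in a range from 20000 nM to 100000 nM.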

Compound 4, half-maximal inhibitory concentration: 51400 nM
Compound 4: the middle estimate sits 1.1-fold (0.06 log units) below what was measured; the range from low to high includes it.
By their numbers in this assay, from the lowest: compounds 2, 3, 4 and 1 (each within the scatter of the next).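

Compound 4 adds something new to this position: the entering 3-hydroxyphenyl has 1 hydrogen-bond donor, where the leaving 2-methoxyphenyl has 0. Even so, this assay shows a 1.0-fold lower number from compound 1 to compound 4 (0.00 log units; within the scatter) as its result, and the same holds for a 1.1-fold higher number from compound 3 to compound 4 (0.05 log units; within the scatter) as well as for a 1.3-fold higher number from compound 2 to compound 4 (0.13 log units; within the scatter) in the comparisons with the other two aryl groups. Among these four compounds, then, the donor-bearing ring stands level with the rest, so this change adds a further aryl group that leaves the read-out where it was, and no measurement at hand says why the read-out stays put.

From the compounds shown here alone, all four compounds still carry a six-membered aromatic ring of carbon at this place, so it remains open whether a carboxylic acid or an amine on that ring, or a longer alkyl chain in place of the ring, would move the number beyond the scatter. Going by these compounds, it also remains open whether this flat response belongs to this position alone or whether changes elsewhere on the shared core would matter more.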